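Cyclic peptide series: side chain variation at one position

A few compounds are considered here, and "the series" means these few. Any claim that something is new, unique, unknown or untested is made for them only; others in the source may bear on it.

Measured so far in a functional assay on P388 cells (Mus musculus) for cytotoxicity; a higher number here means a weaker inhibitor, a lower number a stronger inhibitor:
- compound 1, `COC(=O)CC[C@@H]1NC(=O)[C@@H](C)NC(=O)[C@@H]2Cc3ccc(OC)c(c3)Oc3ccc(cc3)C[C@@H](C(=O)N2C)N(C)C(=O)[C@H](C)NC(=O)[C@H](Cc2ccc(OC)cc2)N(C)C1=O`, gives 58.9 nM
- compound 2, `COc1ccc(C[C@H]2C(=O)N[C@@H](C)C(=O)N(C)[C@H]3Cc4ccc(cc4)Oc4cc(ccc4OC)C[C@@H](C(=O)N[C@H](C)C(=O)N[C@@H](CSC(C)=O)C(=O)N2C)N(C)C3=O)cc1`, gives 9.77 nM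
- compound 3, `COc1ccc(C[C@H]2C(=O)N[C@@H](C)C(=O)N(C)[C@H]3Cc4ccc(cc4)Oc4cc(ccc4OC)C[C@@H](C(=O)N[C@H](C)C(=O)N[C@@H](CCCCO)C(=O)N2C)N(C)C3=O)cc1`, gives 219 nM

Compound 3 carries the highest number of the three, set apart from compound 1 by a 3.7-fold higher number from compound 1 to compound 3 (0.57 log units; beyond the scatter) and from compound 2 by a 22-fold higher number from compound 2 to compound 3 (1.35 log units; beyond the scatter). The next compound, compound 4, `COc1ccc(C[C@H]2C(=O)N[C@@H](C)C(=O)N(C)[C@H]3Cc4ccc(cc4)Oc4cc(ccc4OC)C[C@@H](C(=O)N[C@H](C)C(=O)N[C@@H](CCSC)C(=O)N2C)N(C)C3=O)cc1`, differs from compound 3 in one place: methylsulfanyl in place of 2-hydroxyethyl on a saturated chain carbon, two bonds along the chain from a saturated ring carbon.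

Within the data shown here, two measured steps bear on this change. The step from compound 2 to compound 3 exchanged a sulfur-bearing chain for a hydroxylated one and gave the large rise described as a 22-fold higher number from compound 2 to compound 3 (1.35 log units; beyond the scatter); the step from compound 1 to compound 3 replaced a methoxycarbonyl by 2-hydroxyethyl and gave a 3.7-fold higher number from compound 1 to compound 3 (0.57 log units; beyond the scatter). Both hydroxylated chains sit at the high end, and the only sulfur-bearing chain sits at the low end. Moving from compound 3 to compound 4 removes the hydroxyl and brings in a methylsulfanyl, so a drop beyond the scatter in this assay is expected, though the chain shape of compound 4 matches neither compound 2 nor compound 1 exactly, which widens the range.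

For compound 4 the estimate is 30 nM, between 8 nM and 120 nM, corresponding to an expected step of a 7.3-fold lower number from compound 3 to compound 4 (0.86 log units; beyond the scatter).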

Compound 4, half-maximal inhibitory concentration: 20.4 nM
The estimate for compound 4 lay 1.5-fold (0.17 log units) above the measured number; measured number inside the range.
By their numbers in this assay, from the lowest: compound 2; then compound 4; then compound 1; then compound 3.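

In this assay, the step of an 11-fold lower number from compound 3 to compound 4 (1.03 log units; beyond the scatter) shows that this position responds strongly to a change at the chain end, with methylsulfanyl in place of 2-hydroxyethyl. The acetyl group is not required for a low number, although the step of a 2.1-fold higher number from compound 2 to compound 4 (0.32 log units; beyond the scatter) keeps the acetylsulfanyl chain ahead of the (methylsulfanyl)methyl form, while the step of a 2.9-fold lower number from compound 1 to compound 4 (0.46 log units; beyond the scatter) puts the methylsulfanyl chain ahead of the ester chain; across these four compounds, both sulfur-bearing chains therefore give lower numbers than the two without sulfur, and no compound shown goes against this. No supporting measurement accounts for these differences.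

The compounds shown do not separate an effect of sulfur from one of losing the hydroxyl, and a plain butyl chain or a free thiol at this position would bear directly on that question. From the compounds shown here alone, how the series responds to a terminal amine or a carboxylic acid on the chain, or to a longer chain carrying methylsulfanyl, also remains open.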